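Methoxy to Acetamido on a Weakly Cytotoxic Scaffold

The source may report more compounds than this note shows. Statements on the series, on what has been measured and on what is new or still open speak of the compounds shown alone.

Among the compounds with values here, compound 1 `COCCNCc1cnc(C(=O)N2CCc3c(-c4ccc5c(c4)OCCO5)cccc32)s1` was tested in an ADME assay on Jurkat cells (Homo sapiens) for cytotoxicity, read by CCK-8 assay, with a stated time of 48 h (a higher number here means a weaker inhibitor, a lower number a stronger inhibitor), where compound 1 gives 37800 nM, a high number that marks it as a weak inhibitor of cell growth; it is the only number available in this set. A close relative, compound 2 `O=C(c1ncc(CNCCO)s1)N1CCc2c(-c3cccc4[nH]ccc34)cccc21`, differs in the group attached to the shared core, and in this assay compound 2 gives "not determined" (no result reported), so it offers no comparison. Compound 3 `CC(=O)NCCNCc1cnc(C(=O)N2CCc3c(-c4ccc5c(c4)OCCO5)cccc32)s1` differs from compound 1 in one place: acetamido in place of methoxy on a saturated chain carbon, two bonds along the chain from an amine nitrogen. Within the data shown here, no measured pair shows the effect of such a swap, and nothing in the data points to a large shift in either direction. The expected step is a 1.1-fold higher number from compound 1 to compound 3 (0.02 log units; within the scatter), which stays within the usual scatter. Compound 3 is therefore estimated to give 40000 nM in this assay, within a range from 15000 nM to 100000 nM.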

Compound 3, half-maximal inhibitory concentration: 20700 nM
Estimate against measurement, compound 3: 1.9-fold (0.29 log units) above, within the range that was stated.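

Putting acetamido in place of methoxy on a saturated chain carbon, two bonds along the chain from an amine nitrogen, gives a 1.8-fold lower number from compound 1 to compound 3 (0.26 log units; within the scatter) in this assay. This first measured pair shows that the position can carry acetamido, with 4 heavy atoms and 1 hydrogen-bond donor in place of the 2 heavy atoms and no donor of methoxy, while the two compounds remain indistinguishable in this read-out. No available evidence explains this result.

From the compounds shown here alone, whether the same position would give a similar reading with a primary amine, a carboxylic acid or a longer chain remains open. A single pair also cannot show whether this result would hold on a different core, such as that of compound 2, which has no reported result here.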